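The source may report more compounds than this note shows. Statements on the series, on what has been measured and on what is new or still open speak of the compounds shown alone.

Measured so far in a functional assay on WM 266-4 cells (Homo sapiens) for inhibition, read by MTT assay, with a stated time of 24 h; a lower number here means a stronger inhibitor of growth, a higher number a weaker inhibitor of growth: compound 1 `O=C(c1ccc2c(c1)OCCO2)N1N=C(c2ccccc2)CC1c1ccccc1F` at 2500 nM; compound 2 `O=C(c1ccc2c(c1)OCCO2)N1N=C(c2ccccc2)CC1c1ccccc1` at 1370 nM; compound 3 `COc1ccc(C2=NN(C(=O)c3ccc4c(c3)OCCO4)C(c3ccccc3F)C2)cc1` at 3470 nM.

Compound 1 sits in the middle of these three numbers, with the step of a 1.8-fold lower number from compound 1 to compound 2 (0.26 log units; within the scatter) and the step of a 1.4-fold higher number from compound 1 to compound 3 (0.14 log units; within the scatter) both inside the scatter, so the three compounds are not separated by this assay.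

Compound 4 `O=C(C1COc2ccccc2O1)N1N=C(c2ccccc2)CC1c1ccccc1F` differs from compound 1 by 2,3-dihydro-1,4-benzodioxin-2-yl in place of 2,3-dihydro-1,4-benzodioxin-6-yl on a carbonyl carbon. Neither measured step touches the carbonyl side of the core; both concern substituents on the pendant aromatic rings and both fall within the scatter. Going by the values given here, no measured step therefore bears on this change, and the expectation rests on compound 1 alone, with a wide range and no set direction for the step of no change at the digits printed from compound 1 to compound 4 (within the scatter). Compound 4 is expected at 2500 nM, between 800 nM and 8000 nM.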

Compound 4, concentration for 50% growth inhibition: 1490 nM
The estimate for compound 4 lay 1.7-fold (0.22 log units) above the measured number; the range from low to high includes it.
By their numbers in this assay, from the lowest: compounds 2, 4, 1 and 3 (each within the scatter of the next, the first and the last beyond it).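

Compound 1 and compound 4 carry the same atoms, joined differently, and 2,3-dihydro-1,4-benzodioxin-2-yl in place of 2,3-dihydro-1,4-benzodioxin-6-yl is the only change shown on the carbonyl side of the series. In this assay this change gives a 1.7-fold lower number from compound 1 to compound 4 (0.22 log units; within the scatter), so in this one pair the attachment point of this group does not separate the compounds. No measurement bears on why the step has this size.

From the compounds shown here alone, whether a piperidine or a longer alkyl chain on this carbonyl carbon would give a step beyond the scatter remains open.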